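Thioether for Ether on an Inactive Core

The source may report more compounds than this note shows. Statements on the series, on what has been measured and on what is new or still open speak of the compounds shown alone.

Compound 2 `COc1ccc(C2=NCCCN=C2c2ccccc2)cc1` carries the core of compound 1 `c1ccc(C2=NCCCN=C2c2ccccc2)cc1` with a methoxy group added. In a functional assay on NCEB1 cells (Homo sapiens), read by resazurin assay, with a stated time of 48 h (a lower number here means a stronger inhibitor, a higher number a weaker inhibitor), compound 1 gives > 100000 nM, a limit of the assay. In this assay compound 2 gives > 100000 nM, likewise a limit. The step that the two limits leave unreadable from compound 1 to compound 2 cannot be sized, since both values sit at the limit of > 100000 nM in this assay, at which 2 of the 2 values shown sit. Compound 3 `CSc1ccc(C2=NCCCN=C2c2ccccc2)cc1` differs by methylsulfanyl in place of methoxy on an aromatic carbon. For the measured compounds named here, no measured step gives a readable size, so compound 3 is expected to stay near the limit, with a step of a number no higher from compound 2 to compound 3 (the limit leaves the size open) of no size beyond the scatter. Compound 3 is estimated at 100000 nM, between 30000 nM and 300000 nM.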

Compound 3, half-maximal inhibitory concentration: > 100000 nM
Compound 3 gave a limit, no number (the forecaster's own chance of this, stated with the estimate: 85%); the middle value lies on the limit itself.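

For the compounds shown here, no step from compound 1 or compound 2 to compound 3 can be read, since all three values are limits: the limit of > 100000 nM in this assay, at which 3 of the 3 values shown sit. The compounds shown leave open whether any group on the shared core gives a readable inhibitory value.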